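Fluoro for methyl on the aryl arm of compound 1

The source may report more compounds than this note shows. Statements on the series, on what has been measured and on what is new or still open speak of the compounds shown alone.

Measured compounds:
Compound 1 `Cc1ccc(-c2nc3c(c(-c4ccccc4)nn3-c3ccccc3)c(-c3ccc(O)cc3)c2C#N)cc1` gives 13400 nM in a functional assay on CCRF-CEM cells (Homo sapiens) for antiproliferative activity, read by resazurin assay, with a stated time of 72 h; a lower number here means a stronger inhibitor, a higher number a weaker inhibitor.
Compound 2 `N#Cc1c(-c2cccs2)nc2c(c(-c3ccccc3)nn2-c2ccccc2)c1-c1ccc(O)cc1` returns > 25000 nM, which is a limit of the assay and not a number.
Compound 3 `COc1ccc(-c2nc3c(c(-c4ccccc4)nn3-c3ccccc3)c(-c3ccc(O)cc3)c2C#N)cc1` gives 6700 nM.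

Compound 1 holds the highest of the two numbers obtained, and the nearest is compound 3, reached by a 2.0-fold lower number from compound 1 to compound 3 (0.30 log units; within the scatter), a change that stays within the scatter. Replacing the whole aryl ring gives an at least 1.8-fold higher number from compound 1 to compound 2 (0.27 log units; that floor lies within the scatter), while the reverse path from the thiophene gives an at least 3.7-fold lower number from compound 2 to compound 3 (0.57 log units; beyond the scatter); compound 2 sits at the limit of > 25000 nM in this assay, at which 1 of the 3 values shown sits.

Compound 4 `N#Cc1c(-c2ccc(F)cc2)nc2c(c(-c3ccccc3)nn2-c2ccccc2)c1-c1ccc(O)cc1` is not yet measured. Its change from compound 1 is fluoro in place of methyl on an aromatic carbon. Among the measured compounds shown here, the one measured step that bears directly on it is the exchange of one small group for another on that same aromatic carbon, namely a 2.0-fold lower number from compound 1 to compound 3 (0.30 log units; within the scatter), which did not leave the scatter. The step to compound 2, a change of the entire ring, is a different kind of alteration and is not a close guide. Compound 4 is therefore expected to show no step beyond the scatter, a 1.1-fold lower number from compound 1 to compound 4 (0.05 log units; within the scatter). The estimate for compound 4 is 12000 nM, expected to fall between 5000 nM and 30000 nM.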

Compound 4, half-maximal inhibitory concentration: > 25000 nM
Compound 4: only a limit was reported; the forecaster's own chance of this, stated with the estimate: 25%; middle value at least 2.0-fold (0.31 log units) from the limit.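

In this assay compound 4 gives > 25000 nM, which is a limit of the assay and not a number. On this aromatic carbon, para to a large group, exchanging one small group for another can now move the result beyond the scatter: fluoro in place of methoxy gives an at least 3.7-fold higher number from compound 3 to compound 4 (0.57 log units; beyond the scatter), whereas the earlier methyl to methoxy exchange stayed within it, and fluoro in place of methyl gives an at least 1.8-fold higher number from compound 1 to compound 4 (0.27 log units; that floor lies within the scatter), so only the separation from the methoxy group of compound 3 is established. The step between compound 2 and compound 4 cannot be read, because both values are limits: the limit of > 25000 nM in this assay, at which 2 of the 4 values shown sit.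

From the compounds shown here alone, how far compound 4 and compound 2 actually lie past the limit remains open, so the 4-fluorophenyl and thiophen-2-yl arms cannot be ordered, and the size of the fluoro to methyl difference is also unresolved. Also open, going by these compounds, is whether a group such as an amine, or a longer chain such as ethoxy, on this same carbon would give a lower number than the methoxy group of compound 3.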